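The source may report more compounds than this note shows. Statements on the series, on what has been measured and on what is new or still open speak of the compounds shown alone.

Measured compounds:
- compound 1 `CN(c1cccc2c1CN(c1nc(Nc3cc(C(F)(F)F)cc(C(F)(F)F)c3)ncc1C(F)(F)F)C2)S(C)(=O)=O`: in a functional assay on HepG2 cells (Homo sapiens) for antiproliferative activity, read by spectrophotometry, with a stated time of 2 days (on this read-out higher numbers stand for weaker inhibition of growth and lower numbers for stronger inhibition of growth), compound 1 gives 10300 nM
- compound 2 `CN(c1cccc2c1CN(c1nc(Nc3cc(Cl)cc(C(F)(F)F)c3)ncc1C(F)(F)F)C2)S(C)(=O)=O`: in this assay compound 2 gives 9900 nM

Within the data shown here, compound 2 stands at the lowest of the two numbers so far, but its nearest neighbour is compound 1, and the step of a 1.0-fold lower number from compound 1 to compound 2 (0.02 log units; within the scatter) lies within the scatter, so the two cannot be ordered against each other.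

The next compound is compound 3 `COc1cc(Nc2ncc(C(F)(F)F)c(N3Cc4cccc(N(C)S(C)(=O)=O)c4C3)n2)cc(C(F)(F)F)c1`. Relative to compound 2 it differs as follows: methoxy in place of chloro on an aromatic carbon.

Among the measured compounds shown here, only one measured step exists, the exchange of trifluoromethyl for chloro on the same aromatic carbon, and it was flat: a 1.0-fold lower number from compound 1 to compound 2 (0.02 log units; within the scatter). For the measured compounds named here, no measured step covers methoxy in place of chloro at this position, so there is nothing that points to a change in this assay in either direction. The expectation is therefore a step of about a 1.0-fold higher number from compound 2 to compound 3 (0.00 log units; within the scatter), that is, no change beyond the scatter.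

Compound 3 is estimated at 10000 nM in this assay, with a range of 4000 nM to 25000 nM.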

Compound 3, concentration for 50% growth inhibition: 22100 nM
Compound 3: middle estimate off by 2.2-fold (0.34 log units), on the low side; the measured number falls inside the stated range.
By their numbers in this assay, from the lowest: compounds 2 and 1 (each within the scatter of the next); then compound 3.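

In this assay this aromatic carbon, meta to a trifluoromethyl group, proves not to be indifferent to its substituent: the exchange of chloro for methoxy brings a 2.2-fold higher number from compound 2 to compound 3 (0.35 log units; beyond the scatter), and the exchange of trifluoromethyl for methoxy brings a 2.1-fold higher number from compound 1 to compound 3 (0.33 log units; beyond the scatter). Both steps are modest but beyond the scatter, so methoxy, with its single hydrogen-bond acceptor, separates from the two groups that could not be ordered against each other, and it does so on the side of weaker inhibition of growth. Nothing available on these compounds bears on why the number moves at this position.

Open, on these data alone, is whether the shift belongs to methoxy alone or extends to other groups on this carbon, such as a hydroxyl, an amine or a longer alkoxy chain like ethoxy, and whether any group here can move the number to the lower side. Also open, as far as these compounds go, is whether the same exchange gives a similar step when the trifluoromethyl group on this ring or the shared core is changed.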